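The source may report more compounds than this note shows. Statements on the series, on what has been measured and on what is new or still open speak of the compounds shown alone.

Measured compounds:
- compound 1, `COc1ccc(C(=O)/C(=C/C2CCCCC2)CN(C)C(=O)c2ccccc2)cc1`, in a functional assay on NB-4 cells (Homo sapiens) for inhibition, read by XTT assay, with a stated time of 48 h (on this read-out lower numbers stand for stronger inhibition and higher numbers for weaker inhibition), compound 1 gives 39700 nM
- compound 2, `CC(=O)OC/C(=C/c1ccc(Cl)cc1Cl)C(=O)c1ccccc1`, compound 2 gives 12600 nM
- compound 3, `C=C(C/C(=C\c1ccc(C)cc1)C(=O)c1ccccc1)C(=O)c1ccccc1`, compound 3 gives 7600 nM

Compound 3 holds the lowest of the three numbers in this assay. Its nearest neighbour is compound 2, whose number lies within the usual scatter of the value of compound 3, so the two cannot be told apart on this read-out. Compound 1 stands further off, beyond the scatter, with the weakest inhibition of the three.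

The unmeasured compound 4, `C=C(C/C(=C\c1ccc(OC(=O)c2ccccc2)cc1)C(=O)c1ccccc1)C(=O)c1ccccc1`, keeps the whole skeleton of compound 3 and differs in one place: benzoyloxy in place of methyl on an aromatic carbon. Among the measured compounds shown here, no pair of measured compounds isolates such a change, so there is no measured step to lean on. The benzoyloxy group brings a further aromatic ring and two hydrogen-bond acceptors where compound 3 carries only a methyl, but the three measured values give no guide to how this ring reacts to such an addition.

The step from compound 3 to compound 4 is therefore expected to be small, of the order of the scatter, with no clear direction, as a 1.2-fold lower number from compound 3 to compound 4 (0.07 log units; within the scatter). Compound 4 is estimated to give 6500 nM in this assay, within a range from 2000 nM to 20000 nM.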

Compound 4, half-maximal inhibitory concentration: 8000 nM
The estimate for compound 4 lay 1.2-fold (0.09 log units) below the measured number; the range from low to high includes it.
By their numbers in this assay, from the lowest: compounds 3, 4 and 2 (each within the scatter of the next); then compound 1.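

In this assay, among the compounds shown here, this is the first measured step at any position: a 1.1-fold higher number from compound 3 to compound 4 (0.02 log units; within the scatter) marks the exchange of methyl for benzoyloxy on an aromatic carbon, para to a large group. The read-out therefore does not separate the two compounds, although the entering group brings a further six-membered aromatic ring and two hydrogen-bond acceptors that the methyl lacks, so this position can carry a much larger group without a measurable change for this one pair. No measurement at hand speaks to why the two compounds cannot be told apart.

For the compounds shown here, whether an amine, a carboxylic acid or a hydroxyl group at the same place would leave the number just as unmoved remains open, since methyl and benzoyloxy are the only two groups compared there. Also open, going by these compounds, is whether a change on the other aromatic rings of the shared core would be equally silent, as this single step speaks for one position only.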